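The source may report more compounds than this note shows. Statements on the series, on what has been measured and on what is new or still open speak of the compounds shown alone.

Measured compounds:
- compound 1, `Nc1ccc(S(=O)(=O)N2CCN(c3ncc(C(O)(C(F)(F)F)C(F)(F)F)cc3Br)CC2)cn1`: < 14 mL.min-1.g-1
- compound 2, `Nc1ccc(S(=O)(=O)N2CCN(c3ncc(C(O)(C(F)(F)F)C(F)(F)F)cc3-c3ccncc3)CC2)cn1`: 15 mL.min-1.g-1

In an ADME assay (liver) for metabolic stability, with Liver microsome (Homo sapiens) as the target, using microsomes and NADPH, with a stated time of 30 min, tested at 1 uM (a higher number here means faster removal of the compound, a lower number slower removal), compound 2 gives 15 mL.min-1.g-1, which is the only actual number among the two results shown. Compound 1 does not give a number in this assay; its result, < 14 mL.min-1.g-1, is a limit of the assay. Within the data shown here, that limit, (the limit of < 14 mL.min-1.g-1 in this assay, at which 1 of the 2 values shown sits), is where compound 1 sits, so the one measured step, an at least 1.0-fold higher number from compound 1 to compound 2 (0.02 log units; that floor lies within the scatter), is a floor rather than a true size and stays within the scatter.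

The unmeasured compound 3, `Nc1ccc(S(=O)(=O)N2CCN(c3ncc(C(O)(C(F)(F)F)C(F)(F)F)cc3-c3cc4ccccc4s3)CC2)cn1`, differs from compound 2 in one place: 1-benzothiophen-2-yl in place of pyridin-4-yl on an aromatic carbon. Among the measured compounds shown here, the only step known at this position, the one from bromo to pyridin-4-yl, showed nothing beyond the scatter, and no step involving a 1-benzothiophen-2-yl group has been measured here. The expectation for compound 3 therefore rests on compound 2 alone, and the expected step of a 1.3-fold higher number from compound 2 to compound 3 (0.12 log units; within the scatter) is one that stays within the scatter, with no clear direction. Compound 3 is estimated at 20 mL.min-1.g-1, within a range from 8 mL.min-1.g-1 to 50 mL.min-1.g-1.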

Compound 3, intrinsic clearance in microsomes: < 14 mL.min-1.g-1
Compound 3: no number, only a limit; the forecaster's own chance of this, stated with the estimate: 20%; middle value at least 1.4-fold (0.15 log units) from the limit.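

Compound 3 gives only a limit of the assay in this assay, so the new step, an at least 1.0-fold lower number from compound 2 to compound 3 (0.02 log units; that floor lies within the scatter), is a floor and not a true size. What it adds is that the larger 1-benzothiophen-2-yl, with one five-membered and one six-membered aromatic ring, can stand on this aromatic carbon in place of the single-ring pyridin-4-yl without any sign of faster removal, so across the bromo, pyridin-4-yl and 1-benzothiophen-2-yl groups, a clear rise in the number has yet to appear. The step between compound 1 and compound 3 cannot be read, and the true differences among these groups stay hidden because the results crowd at one end of the scale: the limit of < 14 mL.min-1.g-1 in this assay, at which 2 of the 3 values shown sit.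

The compounds shown leave open how far the true numbers of compound 1 and compound 3 lie from the limit, and so whether the three groups differ at all. They also leave open whether a different kind of group on this carbon, such as an amine, a carboxylic acid or a longer carbon chain, would move the number clearly beyond the scatter.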